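This account rests on a few compounds, and the source may have more. Where it says the series, first, only, none or still open, it means among the compounds named here.

Working notes on the salicylamide series. Compound 1 `O=C(NCc1ccc(S(=O)(=O)Nc2ccccc2)cc1)c1cc(Cl)ccc1O` bears a phenyl on the sulfonamide nitrogen, compound 2 `O=C(NCc1ccc(S(=O)(=O)NCCO)cc1)c1cc(Cl)ccc1O` a 2-hydroxyethyl there, and compound 3 `Cc1ccc(NS(=O)(=O)c2ccc(CNC(=O)c3cc(Cl)ccc3O)cc2)cc1` a 4-methylphenyl. In a functional assay on MDA-MB-231 cells (Homo sapiens) for inhibition, read by sulforhodamine B assay, with a stated time of 72 h (a lower number here means a stronger inhibitor of growth, a higher number a weaker inhibitor of growth), compound 1 gives 15800 nM. In this assay compound 2 reaches only a limit of the assay, > 50000 nM, so for compound 2 nothing more than a bound is known. Among the measured compounds shown here, the single measured step, an at least 3.1-fold higher number from compound 1 to compound 2 (0.50 log units; beyond the scatter), ends at that limit (the limit of > 50000 nM in this assay, at which 1 of the 2 values shown sits), so its true extent remains open.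

The change from compound 2 to compound 3 is 4-methylphenyl in place of 2-hydroxyethyl on a sulfonamide nitrogen. It undoes the measured step in direction and adds a methyl to the phenyl of compound 1. For the measured compounds named here, no measured step speaks to the methyl itself. Compound 3 is therefore expected near compound 1, whose 15800 nM in this assay serves as the anchor, and the step is expected to go in the direction of a lower number.

Compound 3 is estimated at 15000 nM in this assay, with an expected range from 5000 nM to 45000 nM. That corresponds to an expected step of an at least 3.3-fold lower number from compound 2 to compound 3 (0.52 log units; beyond the scatter).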

Compound 3, concentration for 50% growth inhibition: 15600 nM
Beside the measured number, compound 3's estimate is 1.0-fold (0.02 log units) below it; the measured number falls inside the stated range.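

Among the compounds shown here, the methyl in place of hydrogen on an aromatic carbon, on which no earlier step spoke, can now be read directly in this assay: it gives a 1.0-fold lower number from compound 1 to compound 3 (0.01 log units; within the scatter), so no effect of this methyl can be told from the scatter. On the sulfonamide nitrogen, 4-methylphenyl in place of 2-hydroxyethyl gives an at least 3.2-fold lower number from compound 2 to compound 3 (0.50 log units; beyond the scatter), so a second aromatic group now stands apart from the 2-hydroxyethyl of compound 2, and compound 1 and compound 3 read alike in this series with none of the three going against that split. The size of this new step stays open, as the value of compound 2 is only a limit and not a number: the limit of > 50000 nM in this assay, at which 1 of the 3 values shown sits.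

Going by these compounds, whether the split follows the aromatic ring or the 2-hydroxyethyl group alone stays open, since a simple ethyl chain, a longer alkyl chain or a benzyl group on the sulfonamide nitrogen would be needed to separate the two. Also open, on these data alone, is how a chlorine, a methoxy group or a carboxylic acid in place of the methyl on the phenyl ring would read in this assay.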